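Adding One Chloro to Compound 2

The source may report more compounds than this note shows. Statements on the series, on what has been measured and on what is new or still open speak of the compounds shown alone.

Of the compounds shown here, three built around related cores have been measured so far in a functional assay (Platelet, plasma) for inhibition, with Homo sapiens as the target (a higher number here means a weaker inhibitor, a lower number a stronger inhibitor), where the read-out is the half-maximal inhibitory concentration. In this assay compound 2 (`N#Cc1cc2c(nc1N1CCC(C(=O)NS(=O)(=O)Cc3ccccc3)CC1)CCCC2=O`) gives 117000 nM. Compound 1 (`N#Cc1cc2c(nc1N1CC(C(=O)NS(=O)(=O)c3ccc(Cl)s3)C1)COC2=O`) gives 193000 nM, and the two numbers lie within the usual scatter of each other, so neither can be ranked over the other. Compound 3 (`CC1OC(=O)c2cc(C#N)c(N3CCC(C(=O)NS(=O)(=O)Cc4ccccc4)C3)nc21`) gives only a limit, > 300000 nM, and not a true number.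

The next compound, compound 4 (`N#Cc1cc2c(nc1N1CCC(C(=O)NS(=O)(=O)Cc3ccccc3)CC1)CCC(Cl)C2=O`), keeps the structure of compound 2 except for one change: chloro in place of hydrogen on a saturated ring carbon. Within the data shown here, no measured pair here differs in one place, so the data give no direct guide to what this change does. The starting point is therefore compound 2 at 117000 nM, and the expectation is a small shift in this assay, probably no larger than the scatter and with no firm direction. The expected move is a 1.2-fold lower number from compound 2 to compound 4 (0.07 log units; within the scatter). For compound 4 the estimated value is 100000 nM, with an expected range of 40000 nM to 250000 nM.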

Compound 4, half-maximal inhibitory concentration: > 300000 nM
Compound 4 was reported as a limit; the forecaster's own chance of this, stated with the estimate: 15%; middle value at least 3.0-fold (0.47 log units) away from the limit.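

Among these compounds, compound 4 gives the first comparison here between two compounds that differ in one place, so the effect of a single change can now be read directly. Putting chloro in place of hydrogen on a saturated ring carbon of the six-membered non-aromatic ring gives, in this assay, an at least 2.5-fold higher number from compound 2 to compound 4 (0.40 log units; beyond the scatter), and a higher number here means a weaker inhibitor. This ring carbon therefore does not accept the change without a loss, and the loss lies beyond the usual scatter, so it is more than the noise of repeated measurement. The real size of the loss stays unknown, because compound 4 is reported only as a limit and not as a true number: the limit of > 300000 nM in this assay, at which 2 of the 4 values shown sit.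

The compounds shown do not tell whether the loss belongs to chloro itself or would come with any group placed on this ring carbon. A fluoro, a methyl or a hydroxyl group at the same carbon, set against compound 2, would separate those two readings.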